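A few compounds are considered here, and "the series" means these few. Any claim that something is new, unique, unknown or untested is made for them only; others in the source may bear on it.

Compound 1 `Cc1ccc(-c2ccc(C(=O)Nc3ccc(Oc4ccnc5[nH]ccc45)c(F)c3)nc2)cc1` gives 2640 nM in a functional assay on PC-3 cells (Homo sapiens) for cytotoxicity, read by MTT assay, with a stated time of 72 h; a lower number here means a stronger inhibitor, a higher number a weaker inhibitor. For the measured compounds named here, compound 2 `O=C(Nc1ccc(Oc2ccnc3[nH]ccc23)c(F)c1)c1ccc(-c2ccc(F)cc2)cn1` gives 13400 nM in this assay, the higher of the two numbers, and the only recorded step is a 5.1-fold higher number from compound 1 to compound 2 (0.71 log units; beyond the scatter). Compound 3 `O=C(Nc1ccc(Oc2ccnc3[nH]ccc23)c(F)c1)c1ccc(-c2ccc(Cl)cc2)cn1` differs from compound 2 by chloro in place of fluoro on an aromatic carbon. Going by the values given here, no measured step covers this exact exchange; the one step, methyl to fluoro on the same aromatic carbon, shows only that a change there can move the number beyond the scatter. Compound 3 is thus expected to show a modest step of a 2.2-fold lower number from compound 2 to compound 3 (0.35 log units; beyond the scatter) toward a lower number. Compound 3 is estimated at 6000 nM, within 2000 nM to 18000 nM.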

Compound 3, half-maximal inhibitory concentration: 3030 nM
For compound 3 the middle estimate is 2.0-fold (0.30 log units) above the measured one; the measured number falls inside the stated range.
By their numbers in this assay, from the lowest: compounds 1 and 3 (each within the scatter of the next); then compound 2.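

Moving from 4-fluorophenyl to 4-chlorophenyl gives (a 4.4-fold lower number from compound 2 to compound 3 (0.65 log units; beyond the scatter)) in this assay, so this position responds to an exchange of one halogen for another, not only to methyl against fluoro. Chloro and methyl on this aromatic carbon cannot be told apart (a 1.1-fold higher number from compound 1 to compound 3 (0.06 log units; within the scatter)), which leaves fluoro as the one of these three groups that stands apart. Nothing measured here accounts for that difference. The compounds shown leave open whether bromo, a methoxy group or an amine on this carbon would read like chloro and methyl or like fluoro.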